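Replacing the Amino Group of Compound 2 with Fluoro

A few compounds are considered here, and "the series" means these few. Any claim that something is new, unique, unknown or untested is made for them only; others in the source may bear on it.

Within the data shown here, compound 2 `COC(=O)c1sc2cc(C#Cc3ccc(N)cc3)cnc2c1N` holds the lower of the two numbers measured so far: in a functional assay on MCF7 cells (Homo sapiens) for inhibition, read by sulforhodamine B assay, with a stated time of 48 h (a lower number here means a stronger inhibitor of growth, a higher number a weaker inhibitor of growth), compound 2 gives 2600 nM, whereas compound 1 `COC(=O)c1sc2cc(C#Cc3cccc(N)c3)cnc2c1N` gives 10800 nM. Among the measured compounds shown here, the single measured step, a 4.2-fold lower number from compound 1 to compound 2 (0.62 log units; beyond the scatter), concerns only where the amino group sits on the phenyl ring and says nothing about exchanging that group for another. Compound 3 `COC(=O)c1sc2cc(C#Cc3ccc(F)cc3)cnc2c1N` differs from compound 2 by fluoro in place of amino on an aromatic carbon. For the measured compounds named here, no measured pair bears on this exchange, so the expectation rests on the structural change alone: one hydrogen-bond donor and one hydrogen-bond acceptor leave and none enter. On that basis a modest shift toward a weaker inhibitor is expected, with wide uncertainty, summarised as a 1.7-fold higher number from compound 2 to compound 3 (0.24 log units; within the scatter). Compound 3 is therefore estimated to give 4500 nM in this assay, with a likely range from 1200 nM to 17000 nM.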

Compound 3, concentration for 50% growth inhibition: 29000 nM
Compound 3: the middle estimate sits 6.4-fold (0.81 log units) below what was measured; the whole stated range lies below it.
By their numbers in this assay, from the lowest: compound 2; then compound 1; then compound 3.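

Exchanging 4-aminophenyl for 4-fluorophenyl gives an 11-fold higher number from compound 2 to compound 3 (1.05 log units; beyond the scatter) in this assay, so what the ring carries matters here, and not only where the amino group sits. The step from the other amino compound reads a 2.7-fold higher number from compound 1 to compound 3 (0.43 log units; beyond the scatter), which places the fluoro compound behind both amino compounds; among these three, a phenyl ring bearing amino goes with the lower numbers, and no compound goes against this. Nothing available explains why the number rises so sharply with this exchange.

Going by these compounds, it remains open whether the amino group itself is needed or whether a hydroxyl, a methylamino or a dimethylamino group would serve as well. An unsubstituted phenyl ring would show whether fluoro merely fails to help or actively weakens growth inhibition.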